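Swapping the Alkyne-Linked Ring in Phenoxyacetic Acid Antagonists

This account rests on a few compounds, and the source may have more. Where it says the series, first, only, none or still open, it means among the compounds named here.

Compound 1 `CN(c1cccc(C#Cc2cc(Cl)ccc2OCC(=O)O)c1)S(C)(=O)=O`: 122 nM
Compound 2 `O=C(O)COc1ccc(Cl)cc1C#Cc1ccncc1`: 601 nM

Two compounds sharing a phenoxyacetic acid core have been characterised in an assay on CHO cells for displacement of a labelled ligand from prostaglandin D2 receptor 2 (Homo sapiens), read by scintillation counting; on this read-out lower numbers stand for stronger inhibition and higher numbers for weaker inhibition. Compound 1 gives 122 nM in this assay, while compound 2 gives 601 nM, the higher of the two numbers; the gap between compound 2 and compound 1 lies beyond the usual scatter, so compound 2 is the weaker binder here.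

Compound 3 `O=C(O)COc1ccc(Cl)cc1C#Cc1ccc(Cl)cc1` has not yet been measured. Its structure is derived from compound 2 by a single change at the alkyne: 4-chlorophenyl in place of pyridin-4-yl on a triple-bonded carbon. Nothing in the measured pair isolates this exact change, so the size of the step is uncertain. A modest move toward stronger binding is expected, amounting to an estimated step of a 2.7-fold lower number from compound 2 to compound 3 (0.44 log units; beyond the scatter) in this assay, because the closest analogue compound 1 gives 122 nM there. Compound 3 is therefore expected to give about 220 nM, within a range from 60 nM to 700 nM.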

Compound 3, inhibition constant: 60 nM
For compound 3 the middle estimate is 3.7-fold (0.56 log units) above the measured one; the measured number falls inside the stated range.
By their numbers in this assay, from the lowest: compound 3; then compound 1; then compound 2.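

Within the data shown here, at the triple-bonded carbon, 4-chlorophenyl in place of pyridin-4-yl gives the first reading of a single change at this position: in this assay the step is a 10-fold lower number from compound 2 to compound 3 (1.00 log units; beyond the scatter) and lies beyond the usual scatter. The position therefore responds clearly to the identity of the ring it carries, and a carbon-only aromatic ring bearing chlorine is accommodated there. Nothing available explains why the number falls.

Whether the change in this assay comes from adding the chlorine or from losing the ring nitrogen stays open, as a plain phenyl ring does not appear among these compounds. Also open, going by these compounds, is how an amine, a methoxy group or a nitrile would read in place of that chlorine on the same ring.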